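The source may report more compounds than this note shows. Statements on the series, on what has been measured and on what is new or still open speak of the compounds shown alone.

Measured in an ADME assay on a cell-free system (plasma, Mus musculus) for protein binding, read by LC-MS, using ultracentrifugation, with a stated time of 4.2 h, tested at 1000 ng/mL:
- compound 1 `O=C(NNS(=O)(=O)c1ccccc1F)c1cc(F)cc(-n2cccn2)c1`: 98.9%
- compound 2 `O=C(NNS(=O)(=O)c1ccccc1F)c1cc(F)cc(-c2ccccn2)c1`: 98.5%

Within the data shown here, compound 1 has the lower unbound fraction of only two values, but compound 2 lies close by: the one measured step is a 1.4-fold higher unbound fraction from compound 1 to compound 2 (0.13 log units; within the scatter). Compound 3 `O=C(NNS(=O)(=O)c1ccccc1F)c1cccc(-n2cccn2)c1` carries hydrogen in place of fluoro on an aromatic carbon of compound 1: hydrogen in place of fluoro on an aromatic carbon. Among the measured compounds shown here, no measured step makes this change. The step to compound 2 exchanges a different group, so it is only a loose guide to size. No step beyond the scatter is expected in this assay. The estimated step is a 1.3-fold higher unbound fraction from compound 1 to compound 3 (0.10 log units; within the scatter). Compound 3 is expected at 98.6%, with an estimated range from 97.5% to 99.3%.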

Compound 3, plasma protein binding in the Mus musculus assay: 96%
Beside the measured number, compound 3's estimate is 2.9-fold (0.46 log units) (unbound fraction) below it; measured number outside the range, below it.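

Among these compounds, in the Mus musculus assay compound 1 gives 98.9% and compound 3 gives 96% and hydrogen in place of fluoro on this aromatic carbon gives a 3.6-fold higher unbound fraction from compound 1 to compound 3 (0.56 log units; beyond the scatter) and is the first step here beyond the scatter, while the exchange of 1H-pyrazol-1-yl for pyridin-2-yl gave a 1.4-fold higher unbound fraction from compound 1 to compound 2 (0.13 log units; within the scatter) and stayed within it. In a physicochemical assay for solubility, read by nephelometry, in phosphate buffer, measured as kinetic solubility, at pH 6.5 (on this read-out higher numbers stand for higher solubility and lower numbers for lower solubility), compound 1 gives 25 ug/mL and compound 3 gives 50 ug/mL and the same change gives a 2.0-fold higher number from compound 1 to compound 3 (0.30 log units; within the scatter) and does not separate the two compounds. Nothing measured here explains the shift in plasma binding.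

From the compounds shown here alone, whether chloro, methoxy or an amine at this place would leave more of the compound unbound remains open. Also open, going by these compounds, is whether removing the fluoro group has a similar effect when pyridin-2-yl replaces 1H-pyrazol-1-yl.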